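Swapping Benzyloxy for Chloro on the Aryl Ring

The source may hold more compounds than are shown below. What is called first, only, known or untested is meant among the compounds shown, and "the series" means these compounds.

Of the compounds shown here, three with a shared core have been measured in a functional assay on DU-145 cells (Homo sapiens) for cytotoxicity, read by MTT assay, with a stated time of 72 h; a lower number here means a stronger inhibitor, a higher number a weaker inhibitor. Compound 1 `COc1cccc(/C(=C\c2cn(C(C)=O)c3ccc(OCc4ccccc4)cc23)C(=O)O)c1` gives 1080 nM, compound 2 `COc1cc(/C(=C\c2cn(C(C)=O)c3ccc(OCc4ccccc4)cc23)C(=O)O)cc(OC)c1OC` gives 950 nM, and compound 3 `CC(=O)n1cc(/C=C(/C(=O)O)c2ccc(OCc3ccccc3)cc2)c2cc(OCc3ccccc3)ccc21` gives 1410 nM, the highest of the three numbers, though its gaps to compound 1 and compound 2 both lie within the scatter. Compound 4 `CC(=O)n1cc(/C=C(/C(=O)O)c2ccc(Cl)cc2)c2cc(OCc3ccccc3)ccc21` differs from compound 3 by chloro in place of benzyloxy on an aromatic carbon. For the measured compounds named here, the only measured step that changes one group, a 1.1-fold lower number from compound 1 to compound 2 (0.06 log units; within the scatter), also altered the aryl ring attached to the double-bonded chain carbon and barely moved the number, so a change on that ring is expected to stay within the scatter. The estimate for compound 4 is therefore 1400 nM, ranging from 500 nM to 4000 nM, an expected step of a 1.0-fold lower number from compound 3 to compound 4 (0.00 log units; within the scatter).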

Compound 4, half-maximal inhibitory concentration: 1130 nM
Compound 4: middle estimate off by 1.2-fold (0.09 log units), on the high side, within the range that was stated.
By their numbers in this assay, from the lowest: compounds 2, 1, 4 and 3 (each within the scatter of the next).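

Benzyloxy, with its six-membered aromatic ring, gives way to a single chlorine atom on this aromatic carbon, and the number stays within the scatter (a 1.2-fold lower number from compound 3 to compound 4 (0.10 log units; within the scatter)). Compound 4 also sits within the scatter of the compounds carrying methoxy-substituted aryl groups (a 1.2-fold higher number from compound 2 to compound 4 (0.08 log units; within the scatter); a 1.0-fold higher number from compound 1 to compound 4 (0.02 log units; within the scatter)), so across these four compounds this aryl ring tolerates all the groups shown. No measured evidence bears on why these steps are so small. As far as these compounds go, whether an amine or a hydroxyl on this aromatic carbon would move the number beyond the scatter remains open.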